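Benzoate for acetate on the shared core

The compounds below may be only part of what the source reports. "The series", "measured", "known", "first", "only" and "open" are said of these compounds alone.

Compound 1 `CC(=O)O[C@H]1CC[C@]2(C)[C@H](CC[C@@](C)(O)[C@H]2CC[C@@H]2C(C)=CC[C@H]3[C@H](CC[C@]3(C)O)C2(C)C)OC1(C)C` gives 47900 nM in a functional assay on MCF7 cells (Homo sapiens) for antiproliferative activity, read by MTT assay, with a stated time of 72 h; on this read-out higher numbers stand for weaker inhibition and lower numbers for stronger inhibition.
Compound 2 `CC(=O)O[C@H]1CC[C@]2(C)[C@H](CC[C@@](C)(O)[C@H]2CC[C@@H]2C(C)=CC[C@H]3[C@H](CC[C@]3(C)OC(C)=O)C2(C)C)OC1(C)C` gives 39200 nM in this assay.
Compound 3 `CC(=O)O[C@H]1CC[C@]2(C)[C@H](CC[C@@](C)(O)[C@H]2CC[C@@H]2C(C)=CC[C@@H]3C(C)=CC[C@@H]3C2(C)C)OC1(C)C` gives 43500 nM in this assay.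

Among the compounds with values here, compound 1 carries the highest number of the three, but neither compound 3 nor compound 2 is separated from it beyond the scatter; the one single-change step measured so far, a 1.2-fold lower number from compound 1 to compound 2 (0.09 log units; within the scatter), is flat. The three numbers describe one level of activity rather than a trend.

Compound 4 `CC1=CC[C@H]2[C@H](CC[C@]2(C)O)C(C)(C)[C@@H]1CC[C@H]1[C@]2(C)CC[C@H](OC(=O)c3ccc(F)cc3)C(C)(C)O[C@H]2CC[C@@]1(C)O` is the next compound in this assay. Relative to compound 1 the change is 4-fluorophenyl in place of methyl on a carbonyl carbon. Within the data shown here, no measured step touches the carbonyl carbon, so nothing speaks directly to this change. Among the measured compounds shown here, the only comparison available, a 1.2-fold lower number from compound 1 to compound 2 (0.09 log units; within the scatter), concerns a different place and shows that an acetyl added elsewhere on the core left the number where it was. The working expectation is therefore a step of no more than modest size, if anything toward a lower number, and the estimate for compound 4 is framed accordingly as a 1.6-fold lower number from compound 1 to compound 4 (0.20 log units; within the scatter). Compound 4 is expected to give about 30000 nM, with a likely range from 10000 nM to 90000 nM.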

Compound 4, half-maximal inhibitory concentration: 33500 nM
The estimate for compound 4 lay 1.1-fold (0.05 log units) below the measured number; measured number inside the range.
By their numbers in this assay, from the lowest: compounds 4, 2, 3 and 1 (each within the scatter of the next).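

The acetoxy group of compound 1 is now the site of a measured change: with 4-fluorophenyl in place of methyl on the carbonyl carbon, this assay gives a 1.4-fold lower number from compound 1 to compound 4 (0.16 log units; within the scatter) and the step lies within the scatter. This place on the shared core therefore accepts an aromatic ring in place of a methyl with no measurable shift in the number, which the earlier acetyl step, made at a different oxygen, could not show. The series still sits at a single level of activity, now across both a step at that other oxygen and a step at this carbonyl carbon, and no supporting measurement is available to interpret this flat result.

Only methyl and 4-fluorophenyl are shown on this carbonyl carbon, so the part played by the fluorine cannot be separated from that of the ring without the plain phenyl analogue. From the compounds shown here alone, it also remains open whether a group of another kind here, such as a basic amine, a carboxylic acid or a longer alkyl chain, would move the number beyond the scatter.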